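Amide to acid on a benzylic ester scaffold

The compounds below may be only part of what the source reports. "The series", "measured", "known", "first", "only" and "open" are said of these compounds alone.

compound 1 `NC(=O)c1ccc(COC(=O)c2cc(C(F)(F)F)cc(C(F)(F)F)c2)cc1` — > 100000 nM
compound 2 `O=Cc1ccc(COC(=O)c2ccc3c(c2)CCCC3)cc1` — > 100000 nM
compound 3 `CC1(C)CCC(C)(C)c2cc(C(=O)OCc3ccc(C=O)cc3)ccc21` — 48000 nM

In an ADME assay on HEK293 cells (Homo sapiens) for cytotoxicity, read by WST assay (on this read-out higher numbers stand for lower toxicity in this test and lower numbers for higher toxicity in this test), compound 1 reaches only a limit, > 100000 nM. That limit is shared, since it is the limit of > 100000 nM in this assay, at which 2 of the 3 values shown sit. Compound 2 likewise stops at a limit in this assay, > 100000 nM. Within the data shown here, compound 3 is the one compound with a number in this assay, giving 48000 nM. Among the measured compounds shown here, no two of the measured compounds differ in a single place, so no measured step exists to lean on.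

Compound 4 `O=C(O)c1ccc(COC(=O)c2cc(C(F)(F)F)cc(C(F)(F)F)c2)cc1` differs from compound 1 as follows: hydroxy in place of amino on a carbonyl carbon. For the measured compounds named here, with two of three values at the limit and no measured step to guide the size of this change, compound 4 is expected to stay close to where compound 1 stands. For compound 4 the expected value in this assay is 100000 nM, with a range from 50000 nM to 300000 nM. The step of a number no higher from compound 1 to compound 4 (the limit leaves the size open) is expected to be none beyond the scatter, and a limit rather than a number is the likely read-out.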

Compound 4, half-maximal cytotoxic concentration: > 100000 nM
Compound 4: only a limit was reported; the forecaster's own chance of this, stated with the estimate: 70%; the middle value sits exactly at the limit.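

In this assay compound 4 gives only a limit, > 100000 nM. Compound 1 also stands at a limit, so no step can be read from compound 1 to compound 4. The compounds shown leave open whether hydroxy in place of amino on a carbonyl carbon changes this read-out at all, because most values stop at the same point: the limit of > 100000 nM in this assay, at which 3 of the 4 values shown sit.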